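The source may report more compounds than this note shows. Statements on the series, on what has been measured and on what is new or still open speak of the compounds shown alone.

Of the compounds shown here, three that share one core have so far been tested in a functional assay on Ehrlich cells (Mus musculus) for cytotoxicity, read by LDH release, with a stated time of 48 h (on this read-out higher numbers stand for weaker inhibition and lower numbers for stronger inhibition), and they differ only in the group on a carbonyl carbon. In this test, compound 1 `Cc1ccc(OCC(=O)NNC(=O)c2cc3ccccc3oc2=O)c(C(=O)c2cccc(Cl)c2)c1`, which carries 3-chlorophenyl, gives 65400 nM. Compound 2 `Cc1ccc(OCC(=O)NNC(=O)c2cc3ccccc3oc2=O)c(C(=O)c2ccccc2)c1`, which carries plain phenyl, gives 81100 nM, and compound 3 `Cc1ccc(OCC(=O)NNC(=O)c2cc3ccccc3oc2=O)c(C(=O)c2ccccc2Cl)c1`, which carries 2-chlorophenyl, gives 47600 nM. Compound 3 therefore cannot be told apart from the other two, since a 1.4-fold lower number from compound 1 to compound 3 (0.14 log units; within the scatter) and a 1.7-fold lower number from compound 2 to compound 3 (0.23 log units; within the scatter) both stay within the normal spread of repeat measurements.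

The compound still to be tested is compound 4 `Cc1ccc(OCC(=O)NNC(=O)c2cc3ccccc3oc2=O)c(C(=O)c2ccc(Cl)cc2)c1`. It has the same atoms as compound 3, joined differently: 4-chlorophenyl in place of 2-chlorophenyl on a carbonyl carbon. In words, this is 4-chlorophenyl in place of 2-chlorophenyl on a carbonyl carbon. The closest measured parallel is the swap of 3-chlorophenyl for 2-chlorophenyl, a 1.4-fold lower number from compound 1 to compound 3 (0.14 log units; within the scatter). Removing the chloro group altogether, a 1.2-fold higher number from compound 1 to compound 2 (0.09 log units; within the scatter), also stays within the scatter, as does adding it, a 1.7-fold lower number from compound 2 to compound 3 (0.23 log units; within the scatter). Within the data shown here, none of these three small steps points to a large effect, although no measured compound yet carries 4-chlorophenyl.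

No step beyond the scatter is therefore expected in this assay, and the estimated step is a 1.3-fold higher number from compound 3 to compound 4 (0.10 log units; within the scatter). For compound 4 the estimated value is 60000 nM, with an expected range from 32000 nM to 110000 nM.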

Compound 4, half-maximal inhibitory concentration: 58000 nM
Compound 4: the middle estimate sits 1.0-fold (0.01 log units) above what was measured; the range from low to high includes it.
By their numbers in this assay, from the lowest: compounds 3, 4, 1 and 2 (each within the scatter of the next).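

With 4-chlorophenyl now included in this assay, all three chlorophenyl groups on the carbonyl carbon have been compared, and they cannot be told apart: there is a 1.2-fold higher number from compound 3 to compound 4 (0.09 log units; within the scatter) and a 1.1-fold lower number from compound 1 to compound 4 (0.05 log units; within the scatter). The new compound also cannot be separated from the one carrying plain phenyl, with a 1.4-fold lower number from compound 2 to compound 4 (0.15 log units; within the scatter), so 4-chlorophenyl behaves like 2-chlorophenyl and 3-chlorophenyl in this comparison. Across these four compounds, neither having a chloro group on this phenyl ring nor its placement separates one compound from another in this assay, and none of the four goes against this.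

Nothing available here explains this flat picture. As far as these compounds go, it remains open whether a different kind of group, such as an amine or a carboxylic acid on the phenyl ring, or a cyclohexyl ring in place of the phenyl, would give a step beyond the scatter, and whether the same flat picture would appear on cells other than those used in this assay.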